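The source may report more compounds than this note shows. Statements on the series, on what has been measured and on what is new or still open speak of the compounds shown alone.

Working notes on the series, read in an ADME assay on HEp-2 cells (Homo sapiens) for cytotoxicity; a lower number here means that less compound is tolerated, a higher number that more compound is tolerated. Compound 1 (`CC(C)CCn1c(Cn2c(=O)n(C(C)C)c3ccccc32)nc2c(CN)cccc21`) gives 7000 nM, and compound 2 (`CC(C)CCn1c(Cn2c(=O)n(CC(=O)OC(C)(C)C)c3ccccc32)nc2cc(C(=N)N)ccc21`) gives 7900 nM. Within the data shown here, these two values lie within the scatter of each other, so compound 1 stands level with the only other measured compound. Among the measured compounds shown here, the two differ in more than one place, and the series so far holds no measured step at a single place.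

Compound 3 (`CC(C)CCn1c(Cn2c(=O)n(C(C)C)c3ccccc32)nc2c(CO)cccc21`) keeps the core of compound 1 and changes one group: hydroxy in place of amino on a saturated chain carbon bound to an aromatic carbon. This puts hydroxy in place of amino on a saturated chain carbon bound to an aromatic carbon, which can also be read as aminomethyl to hydroxymethyl.

For the measured compounds named here, no measured step speaks to this change, so the expectation in this assay starts from compound 1 at 7000 nM and stays cautious. The estimated 1.3-fold higher number from compound 1 to compound 3 (0.11 log units; within the scatter) is small, upward if it has any direction, and it may well stay within the scatter. For compound 3 the estimate is 9000 nM, with an expected range of 3500 nM to 25000 nM.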

Compound 3, half-maximal cytotoxic concentration: 22000 nM
For compound 3 the middle estimate is 2.4-fold (0.39 log units) below the measured one, and the stated range covers the measured number.
By their numbers in this assay, from the lowest: compounds 1 and 2 (each within the scatter of the next); then compound 3.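

In this assay, among these compounds, hydroxy in place of amino on a saturated chain carbon bound to an aromatic carbon gives a 3.1-fold higher number from compound 1 to compound 3 (0.50 log units; beyond the scatter), the first step that can be read at a single place. The step shows that this place is not indifferent to the group it carries: one nitrogen leaves and one oxygen enters, while the computed counts of heavy atoms, hydrogen-bond donors and acceptors and the net charge stay the same on both sides, and the number still moves beyond the scatter. Nothing at hand bears on what lies behind this step.

With a single step at this place, the compounds shown leave open whether the aminomethyl to hydroxymethyl change is part of a wider trend or stands alone, and whether a methoxy group, a dimethylamino group or a carboxylic acid on the same saturated chain carbon would lie nearer to compound 1 or to compound 3. They also leave open whether the same exchange gives a step of similar size when the isopropyl group of the core of compound 1 is replaced by another group.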